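Swapping Thiophene for Phenyl on an Inactive Pyridone

The compounds below may be only part of what the source reports. "The series", "measured", "known", "first", "only" and "open" are said of these compounds alone.

Of the compounds shown here, three have been tested in a functional assay on CCRF-CEM cells (Homo sapiens) for inhibition, read by sulforhodamine B assay, with a stated time of 48 h; a lower number here means a stronger inhibitor of growth, a higher number a weaker inhibitor of growth. Compound 1 `CC1CCCc2c1nc(N)c(C#N)c2-c1cccn1C` returns > 100000 nM, which is a limit of the assay rather than a measured number. Compound 2 `Cn1cccc1-c1cc(-c2cccs2)[nH]c(=O)c1C#N` likewise reaches only a limit, > 100000 nM, so its growth inhibition was too weak to be pinned to a value. Compound 3 `COc1ccc(-c2cc(-c3cccn3C)c(C#N)c(N)n2)cc1OC`, built on a different shared core with an amino group and a dimethoxyphenyl group, gives 10 nM in this assay. Compound 2 thus sits at the weak end of what has been seen, sharing with compound 1 (the limit of > 100000 nM in this assay, at which 2 of the 3 values shown sit).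

Compound 4 `Cn1cccc1-c1cc(-c2ccccc2)[nH]c(=O)c1C#N`, not yet measured, differs from compound 2 in a single place: phenyl in place of thiophen-2-yl on an aromatic carbon, in words phenyl in place of thiophen-2-yl on an aromatic carbon. Among the compounds with values here, no measured pair shows this swap, so no direction can be read from the numbers at hand. Because compound 2 already sits at > 100000 nM, the expectation is that the exchange produces no step beyond the scatter, and that compound 4 also comes back as a limit. The expected step in this assay is a number no higher from compound 2 to compound 4 (the limit leaves the size open). Compound 4 is estimated at 100000 nM, within a range of 20000 nM to 300000 nM.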

Compound 4, concentration for 50% growth inhibition: > 100000 nM
Compound 4: no number, only a limit; the forecaster's own chance of this, stated with the estimate: 80%; the middle value sits exactly at the limit.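

Compound 2 and compound 4 both return only a limit of the assay, so the exchange of thiophen-2-yl for phenyl between them cannot be read as a step. The compounds shown leave open whether these two groups differ at all in growth inhibition, and what change to this shared core could bring a measurable value.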